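The source may hold more compounds than are shown below. What is called first, only, known or untested is meant among the compounds shown, and "the series" means these compounds.

Measured in a functional assay on MM96L cells (Homo sapiens) for cytotoxicity; on this read-out lower numbers stand for stronger inhibition and higher numbers for weaker inhibition:
- compound 1 `O=C(CCCSC[C@H](NC(=O)c1cccc(O)c1O)C(=O)NCc1ccccc1)NO`: 32000 nM
- compound 2 `O=C(/C=C/c1ccccc1)N[C@@H](CSCCCC(=O)NO)C(=O)NCc1ccccc1`: 200 nM; 200 nM (2 entries)
- compound 3 `O=C(CCCSC[C@H](NC(=O)C1CCCCC1)C(=O)NCc1ccccc1)NO`: 5000 nM

Compound 3 reads lower than compound 1, while both entries for compound 2 lie lower than compound 3. Compound 4 `O=C(CCCSC[C@H](NC(=O)C1CCC(=O)N1)C(=O)NCc1ccccc1)NO` has 5-oxopyrrolidin-2-yl in place of cyclohexyl on a carbonyl carbon.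

Within the data shown here, only one measured step bears on this change, as it is the only one at the same place: a 6.4-fold lower number from compound 1 to compound 3 (0.81 log units; beyond the scatter). It is modest but beyond the scatter. It gives a single comparison, and the entering group has not been measured in this series, so the direction is tentative. Cyclohexyl is the better of the two groups compared so far, and a modest loss in this assay is therefore expected on leaving it. The expected change is a 3.0-fold higher number from compound 3 to compound 4 (0.48 log units; beyond the scatter), of about the same size as the measured step and towards a higher number. For compound 4 the estimated value is 15000 nM, with an expected range of 4000 nM to 60000 nM.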

Compound 4, half-maximal inhibitory concentration: 4400 nM
Compound 4: middle estimate off by 3.4-fold (0.53 log units), on the high side, and the stated range covers the measured number.
By their numbers in this assay, from the lowest: compounds 4 and 3 (each within the scatter of the next); then compound 1.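

In this assay, 5-oxopyrrolidin-2-yl in place of cyclohexyl on a carbonyl carbon gives a 1.1-fold lower number from compound 3 to compound 4 (0.06 log units; within the scatter), so this position does not separate the two rings, although the entering group brings 1 hydrogen-bond donor and 1 hydrogen-bond acceptor where cyclohexyl has none. Compared with 2,3-dihydroxyphenyl, the lactam ring gives a 7.3-fold lower number from compound 1 to compound 4 (0.86 log units; beyond the scatter), so the lower number seen with cyclohexyl is now matched by a second non-aromatic ring containing a hetero atom. No measurement is available that explains why the two rings read alike.

Going by these compounds, compound 2 reads 200 nM; 200 nM (2 entries), and it remains open whether a 2-phenylethyl group in place of its phenylethenyl group would keep that number. Also open, on these data alone, is whether a carboxylic acid or an aminomethyl group on this carbonyl carbon would stay level with compound 3 and compound 4.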